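The compounds below may be only part of what the source reports. "The series", "measured", "known", "first", "only" and "open" are said of these compounds alone.

Measured so far:
- compound 1, `CCC(CC)Nc1nc(OC)c(-c2ccc(Cl)cc2Cl)nc1C`, 0.933 h
- compound 2, `CCc1nc(-c2ccc(Cl)cc2Cl)c(CC)nc1NC(CC)CC`, 0.283 h
- compound 3, `CCc1nc(-c2ccc(Cl)cc2Cl)c(CC)nc1SC(C)CC`, 0.283 h

In an in vitro ADME assay on microsomes (Homo sapiens) for metabolic stability (on this read-out higher numbers stand for a longer-lived compound and lower numbers for a shorter-lived compound), compound 2 gives 0.283 h and stands level with compound 3, the two together the lowest of the three numbers; compound 1, the furthest from it, gives 0.933 h, a gap beyond the scatter. The step under study leads from compound 2 to compound 4, `CCc1nc(-c2ccc(Cl)cc2Cl)c(OC)nc1NC(CC)CC`, which is not yet measured in this assay. The change is methoxy in place of ethyl on an aromatic carbon.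

For the measured compounds named here, the one measured step, no change at the digits printed from compound 2 to compound 3 (within the scatter), concerns a different position and a different exchange, so it tells little about this one. Going by the values given here, no measured step covers the methoxy-for-ethyl exchange alone. Compound 1 does carry a methoxy group on its core and gives the higher of the measured numbers, but it differs from compound 2 in two places, so its value can only hint at the direction. The expectation for compound 4 is therefore a modest rise, a 1.9-fold higher number from compound 2 to compound 4 (0.29 log units; within the scatter), with wide uncertainty. Compound 4 is estimated at 0.55 h, in a range from 0.28 h to 1.1 h.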

Compound 4, half-life: 0.7 h
For compound 4 the middle estimate is 1.3-fold (0.10 log units) below the measured one; measured number inside the range.
By their numbers in this assay, from the lowest: compounds 2 and 3 (each within the scatter of the next); then compounds 4 and 1 (each within the scatter of the next).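

In this assay, methoxy in place of ethyl on the aromatic carbon next to the ring nitrogen now has a step of its own, and it lies beyond the scatter: a 2.5-fold higher number from compound 2 to compound 4 (0.39 log units; beyond the scatter). Compound 1 had only hinted at this direction, since it differs from compound 2 in two places. Compound 4 separates those two places: methyl in place of hydrogen on a saturated chain carbon bound to an aromatic carbon gives a 1.3-fold lower number from compound 1 to compound 4 (0.12 log units; within the scatter), which stays within the scatter. Nothing at hand says what lies behind the step at the methoxy position.

As far as these compounds go, whether a different group on this carbon, such as an ethoxy group or an amine, would give a higher or lower number remains open. So does whether the methoxy step would hold with the (sec-butyl)sulfanyl group of compound 3 in place of the (pentan-3-yl)amino group.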